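The source may report more compounds than this note shows. Statements on the series, on what has been measured and on what is new or still open speak of the compounds shown alone.

Three compounds share one core and differ only in the aryl group that sits on the chain. Compound 1 `COc1cccc(/C=C/C(=O)c2ccccc2NC(=O)NS(=O)(=O)c2ccc(C)cc2)c1` gives 23.2 ug/mL in an ADME assay on the whole organism for cytotoxicity, with Artemia salina as the target, with a stated time of 24 h; on this read-out higher numbers stand for an effect only at larger amounts of compound and lower numbers for an effect already at smaller amounts. Compound 2 `COc1ccc(/C=C/C(=O)c2ccccc2NC(=O)NS(=O)(=O)c2ccc(C)cc2)cc1OC` gives 12.9 ug/mL in this assay, and compound 3 `CCOc1cc(/C=C/C(=O)c2ccccc2NC(=O)NS(=O)(=O)c2ccc(C)cc2)ccc1O` gives 19.2 ug/mL in this assay. Compound 3 thus stands second highest of the three numbers; nearest to it is compound 1, furthest compound 2, and both gaps lie within the scatter, so no order among the three can be read from them. The change to compound 4 `Cc1ccc(S(=O)(=O)NC(=O)Nc2ccccc2C(=O)/C=C/c2ccccc2[N+](=O)[O-])cc1` is 2-nitrophenyl in place of 3-ethoxy-4-hydroxyphenyl on a double-bonded chain carbon bound to a double-bonded chain carbon. Two measured steps alter the same aryl group and so bear on this one: a 1.2-fold lower number from compound 1 to compound 3 (0.08 log units; within the scatter) and a 1.5-fold higher number from compound 2 to compound 3 (0.17 log units; within the scatter). Both lie within the scatter, and swapping one aryl for another has so far moved nothing beyond it. For compound 4 a step of a 1.1-fold lower number from compound 3 to compound 4 (0.03 log units; within the scatter) is therefore expected, with no direction beyond the scatter. The value of compound 4 in this assay is estimated at 18 ug/mL, between 9 ug/mL and 36 ug/mL.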

Compound 4, concentration for half-maximal effect: 40.1 ug/mL
Estimate against measurement, compound 4: 2.2-fold (0.35 log units) below, outside the stated range (above it).
By their numbers in this assay, from the lowest: compounds 2, 3, 1 and 4 (each within the scatter of the next, the first and the last beyond it).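

Replacing the aryl group on the chain now moves the read-out beyond the scatter: the change to 2-nitrophenyl gives a 2.1-fold higher number from compound 3 to compound 4 (0.32 log units; beyond the scatter) and a 3.1-fold higher number from compound 2 to compound 4 (0.49 log units; beyond the scatter), both modest, so in this assay the choice of group at this position is not without effect. Compound 1 goes against a general shift, as a 1.7-fold higher number from compound 1 to compound 4 (0.24 log units; within the scatter) stays within the scatter, so compound 4 stands apart only from compound 2 and compound 3. Nothing available gives a reason for these steps.

In compound 4 the nitro group enters as the ethoxy, hydroxy or methoxy groups leave, so the contribution of each change stays unresolved. From the compounds shown here alone, how an aryl group carrying an amine or a carboxylic acid would read at this place in this assay also remains open.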